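Aromatic substituent replacements on the shared core toward compound 4

The source may hold more compounds than are shown below. What is called first, only, known or untested is meant among the compounds shown, and "the series" means these compounds.

Measured so far:
compound 1 `CC(=O)c1ccc2c(c1)C(n1ccccc1=O)=CC(C)(C)O2`: 7.37
compound 2 `CC1(C)C=C(n2ccccc2=O)c2cc(C(=O)c3ccccc3)ccc2O1`: 6.61
compound 3 `CC1(C)C=C(n2ccccc2=O)c2cc(C(=N)S)ccc2O1`: 6.21

All three share one core and differ only in the group on the aromatic carbon. In a functional assay (aorta) with Rattus norvegicus as the target (on this read-out lower numbers stand for lower potency and higher numbers for higher potency (the scale is a negative logarithm)), compound 3 stands lowest of the three numbers; compound 2 is nearest and compound 1 furthest, both higher and both beyond the scatter. The step of a number 1.16 log units lower from compound 1 to compound 3 (beyond the scatter) is large, and a number 0.40 log units lower from compound 2 to compound 3 (beyond the scatter) is modest, so the group of 3 heavy atoms (1 carbon, 1 nitrogen, 1 sulfur) has so far been the weakest substituent at that position.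

Compound 4 `CC1(C)C=C(n2ccccc2=O)c2cc(C(F)(F)F)ccc2O1` carries the change (a group of 4 heavy atoms (1 carbon, 3 fluorine; no ring) in place of a group of 3 heavy atoms (1 carbon, 1 nitrogen, 1 sulfur; no ring), on an aromatic carbon). Among the measured compounds shown here, no measured step introduces trifluoromethyl, so the only bearing data are the two steps that remove the carbon-nitrogen-sulfur group: reversing either of them gives a rise. The expectation is therefore a rise in this assay from compound 3 to compound 4, of a size between the two measured steps, with wide uncertainty since the trifluoromethyl group itself is unprecedented in the series. The step of a number 0.49 log units higher from compound 3 to compound 4 (beyond the scatter) is the estimate. Compound 4 is expected at 6.7, with a range from 6 to 7.4.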

Compound 4, logarithm of the reciprocal of the active concentration, log(1/C): 7.61
Compound 4: middle estimate off by 0.91 log units, on the low side; measured number above the stated range.
By their numbers in this assay, from the lowest: compound 3; then compound 2; then compounds 1 and 4 (each within the scatter of the next).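

Before compound 4, every group on this aromatic carbon held oxygen or nitrogen, and the numbers left open whether such an atom mattered here. In this assay, trifluoromethyl, with no hydrogen-bond donors or acceptors, stands level with the acetyl group of compound 1, as a number 0.24 log units higher from compound 1 to compound 4 (within the scatter) shows, so a carbonyl at this position is not needed to reach the top of this small set. Its clear lead over the other two groups appears in a number 1.00 log units higher from compound 2 to compound 4 (beyond the scatter) and in a number 1.40 log units higher from compound 3 to compound 4 (beyond the scatter), which places the carbon-nitrogen-sulfur group and benzoyl as the two replacements that cost potency, while no measurement in hand accounts for these differences.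

From the compounds shown here alone, whether the position also tolerates other groups, such as a nitrile, a methoxy group, an amine or a carboxylic acid, remains open, and with so few groups no trend across them can be drawn. Going by these compounds, all four compounds keep the rest of the shared core unchanged, so it is also open whether the level standing of trifluoromethyl and acetyl would hold with a different group elsewhere on that core.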